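Aminoquinoxaline thioether: chlorines out, fluorine in

A few compounds are considered here, and "the series" means these few. Any claim that something is new, unique, unknown or untested is made for them only; others in the source may bear on it.

Compound 1 `Nc1cc(N)c2nc(-c3ccccc3)c(NCc3ccc(F)cc3)nc2c1`: in a functional assay on NCI-H522 cells (Homo sapiens) for inhibition, read by sulforhodamine B assay, with a stated time of 48 h (a lower number here means a stronger inhibitor of growth, a higher number a weaker inhibitor of growth), compound 1 gives only a limit, < 100000 nM.
Compound 2 `Nc1cc(N)c2nc(-c3ccccc3)c(Sc3ccc(Cl)c(Cl)c3)nc2c1`: in this assay compound 2 gives 33900 nM.

Compound 2 holds the only number shown in this assay; the other value is a limit (the limit of < 100000 nM in this assay, at which 1 of the 2 values shown sits). The step that the limit leaves unreadable from compound 1 to compound 2 therefore cannot be read for size. Compound 3 `Nc1cc(N)c2nc(-c3ccccc3)c(Sc3ccc(F)cc3)nc2c1` differs from compound 2 by 4-fluorophenyl in place of 3,4-dichlorophenyl on a sulfur. Within the data shown here, no measured step touches this sulfur-linked aryl group, so the direction of the change is open. Compound 3 is expected to stay near compound 2, with the step of a 1.2-fold higher number from compound 2 to compound 3 (0.07 log units; within the scatter) taken as within the scatter and a wide band around it. Compound 3 is estimated at 40000 nM, between 15000 nM and 100000 nM.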

Compound 3, concentration for total growth inhibition: < 100000 nM
Compound 3: a limit, no number; the forecaster's own chance of this, stated with the estimate: 30%; the middle value lies beyond the limit too.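

In this assay compound 3 gives only a limit, < 100000 nM, so no step linking compound 1, compound 2 and compound 3 can be read for size: the limit of < 100000 nM in this assay, at which 2 of the 3 values shown sit.

The compounds shown leave open how 4-fluorophenyl compares with 3,4-dichlorophenyl on the sulfur.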